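From a Methyl to a Methoxy on the Amide Aryl Ring

The compounds below may be only part of what the source reports. "The series", "measured", "known", "first", "only" and "open" are said of these compounds alone.

Compound 3 `Cc1ccc(C(=O)Nc2cc(-c3ccccc3)nn2-c2ccccc2)cc1` gives 64 nM in a functional assay on cells for positive allosteric modulation of metabotropic glutamate receptor 5 (Rattus norvegicus), read by calcium flux; on this read-out higher numbers stand for an effect only at larger amounts of compound and lower numbers for an effect already at smaller amounts. Among the three measured compounds it stands second highest: compound 2 `O=C(Nc1cc(-c2ccccc2)nn1-c1ccccc1)c1cccc([N+](=O)[O-])c1` gives 39 nM, and the step of a 1.6-fold higher number from compound 2 to compound 3 (0.22 log units; within the scatter) stays within the scatter, while compound 1 `O=C(Nc1cc(-c2ccccc2)nn1-c1ccccc1)c1cccc(C(F)(F)F)c1` gives 228 nM, and the step of a 3.6-fold lower number from compound 1 to compound 3 (0.55 log units; beyond the scatter) lies beyond it. The remaining step, a 5.8-fold lower number from compound 1 to compound 2 (0.77 log units; beyond the scatter), was the largest seen. Compound 4 `COc1ccc(C(=O)Nc2cc(-c3ccccc3)nn2-c2ccccc2)cc1` carries the change (methoxy in place of methyl on an aromatic carbon). Going by the values given here, no measured step swaps these two groups, and the three steps seen were at most modest. Compound 4 is therefore expected to give 70 nM, with a range from 25 nM to 200 nM. The step of a 1.1-fold higher number from compound 3 to compound 4 (0.04 log units; within the scatter) is expected to remain within the scatter.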

Compound 4, half-maximal effective concentration: 54 nM
Compound 4: the middle estimate sits 1.3-fold (0.11 log units) above what was measured, and the stated range covers the measured number.
By their numbers in this assay, from the lowest: compounds 2, 4 and 3 (each within the scatter of the next); then compound 1.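

On the aromatic carbon para to a large group, methyl and methoxy cannot be told apart in this assay: exchanging them gives a 1.2-fold lower number from compound 3 to compound 4 (0.07 log units; within the scatter) and the extra oxygen leaves no readable mark on this number. Moving to the 4-methoxyphenyl group gives a 1.4-fold higher number from compound 2 to compound 4 (0.14 log units; within the scatter) from 3-nitrophenyl, which stays within the scatter, and a 4.2-fold lower number from compound 1 to compound 4 (0.63 log units; beyond the scatter) from 3-(trifluoromethyl)phenyl, which lies beyond it. No measured evidence bears on these results.

Going by these compounds, whether an amine, a hydroxyl or a longer chain such as ethoxy would fit this position stays open. So does how methoxy behaves on the ring's other carbons.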